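The compounds below may be only part of what the source reports. "The series", "measured", "known", "first", "only" and "open" are said of these compounds alone.

Of the compounds shown here, three have been measured in a physicochemical assay for lipophilicity, read by HPLC, in phosphate buffer, measured as octanol-water partition, at pH 7.4 (on this read-out higher numbers stand for higher lipophilicity and lower numbers for lower lipophilicity), and a fourth is still waiting. Compound 1, with the structure `CC(=O)N[C@@H](C)C(=O)N(C)/N=N/c1ccc(C(N)=O)cc1`, gives 0.69 in this assay. Compound 2, `CC(=O)N[C@H](C(=O)N(C)/N=N/c1ccc(C#N)cc1)C(C)C`, gives 2.18, and compound 3, `CCCC(=O)N[C@@H](C)C(=O)N(C)/N=N/c1ccc(C#N)cc1`, gives 2.28. Compound 1 therefore stands lowest of the three, with compound 2 the nearest to it and compound 3 the furthest, and both of those gaps are beyond the usual scatter. Neither compound 2 nor compound 3 differs from compound 1 in a single place, so those gaps cannot be read as single steps.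

Compound 4, `CC(=O)N[C@@H](C)C(=O)N(C)/N=N/c1ccc(C)cc1`, is the compound still to be measured. It differs from compound 1 in one place only: methyl in place of carbamoyl on an aromatic carbon. Compound 1 sits at 0.69, while the larger nitrile-bearing compound 2 already reaches 2.18 and compound 3 reaches 2.28. On that basis a step upward well beyond the scatter is expected for compound 4, as the carbamoyl that leaves carries a donor and an acceptor and the methyl that enters carries none. The expected step from compound 1 to compound 4 is a number 1.81 log units higher from compound 1 to compound 4 (beyond the scatter) in this assay. Compound 4 is accordingly estimated at 2.5, with a likely range from 1.9 to 3.1.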

Compound 4, partition coefficient: 2.45
For compound 4 the middle estimate is 0.05 log units above the measured one, within the range that was stated.
By their numbers in this assay, from the lowest: compound 1; then compounds 2, 3 and 4 (each within the scatter of the next).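

In this assay, the change of carbamoyl to methyl on an aromatic carbon, para to a large group, gives a number 1.76 log units higher from compound 1 to compound 4 (beyond the scatter). Going by these compounds alone, this is the first gap in the set that can be tied to one place, since everything else in the core of compound 1 stays the same, whereas the earlier gaps involved changes in more than one place. The swap removes a group of three heavy atoms with one hydrogen-bond donor and one hydrogen-bond acceptor and puts in a single carbon with neither, but the size of the group and its donor and acceptor count change together, so this one step cannot separate them, and no measurement shown here gives a reason for the step.

On these data alone, how an amine, a carboxylic acid or a longer chain such as propyl at this same place would compare with methyl and carbamoyl remains open. Compound 2 and compound 3 carry a nitrile there but also differ from compound 1 and compound 4 elsewhere, so the effect of the nitrile alone, and whether this step would be the same size with another acyl chain or side chain, also stay unanswered.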